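The compounds below may be only part of what the source reports. "The series", "measured", "known", "first", "only" and "open" are said of these compounds alone.

Of the compounds shown here, three built on one shared core have been tested in an ADME assay on BHK-21 cells (Mesocricetus auratus) for cytotoxicity, with a stated time of 3 days; a lower number here means that less compound is tolerated, a higher number that more compound is tolerated. Compound 1 `O=C(CCSc1nnc(-c2ccncc2)s1)Nc1ccccc1` carries a plain phenyl on its amide nitrogen. In this assay compound 1 gives > 50000 nM, which is a limit of the assay rather than a number. Compound 2 `O=C(CCSc1nnc(-c2ccncc2)s1)Nc1c(Cl)cccc1Cl` carries a 2,6-dichlorophenyl on that nitrogen, and in this assay compound 2 gives 10300 nM. Compound 3 `O=C(CCSc1nnc(-c2ccncc2)s1)NCc1ccccc1Cl` carries a 2-chlorobenzyl on the amide nitrogen. In this assay compound 3 gives > 50000 nM, again a limit of the assay and not a number. The measured steps are an at least 4.8-fold lower number from compound 1 to compound 2 (0.68 log units; beyond the scatter), an at least 4.8-fold higher number from compound 2 to compound 3 (0.68 log units; beyond the scatter) and a step that the two limits leave unreadable from compound 1 to compound 3. Compound 3 thus stands at the limit of > 50000 nM in this assay, at which 2 of the 3 values shown sit, so it is among the better-tolerated members of the set as far as the numbers can show.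

Compound 4 `CC(CSc1nnc(-c2ccncc2)s1)C(=O)NCc1ccccc1Cl` differs from compound 3 by methyl in place of hydrogen on a saturated chain carbon bound to a carbonyl carbon and a saturated chain carbon. Within the data shown here, none of the measured steps touches this place, since all of them swap the group on the amide nitrogen, so no measured step bears directly on this change. The expectation is therefore a step of no size beyond the scatter, with the value most likely remaining at the limit. Compound 4 is expected to give 60000 nM, within a range from 25000 nM to 150000 nM. This expected result corresponds to a step that the limit leaves unreadable from compound 3 to compound 4.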

Compound 4, half-maximal cytotoxic concentration: > 50000 nM
Compound 4 ended at the assay's limit; the forecaster's own chance of this, stated with the estimate: 70%; the middle value does not contradict the limit.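

In this assay compound 4 gives > 50000 nM, a limit of the assay and not a number. Among these compounds, compound 3 also sits at a limit, so no step between compound 3 and compound 4 can be read: the limit of > 50000 nM in this assay, at which 3 of the 4 values shown sit. The compounds shown leave open whether methyl in place of hydrogen on this saturated chain carbon changes how much compound is tolerated.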